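Replacing a Hydroxycyclohexyl Sulfide with Methoxymethyl

A few compounds are considered here, and "the series" means these few. Any claim that something is new, unique, unknown or untested is made for them only; others in the source may bear on it.

Measured compounds:
Compound 1, `CC(C)c1n[nH]c2c(NCc3ccc(-c4ccccn4)cc3)nc(SCC(C)(C)O)nc12`: in a functional assay on HT cells (Homo sapiens) for antiproliferative activity, read by fluorescence, with a stated time of 72 h (a higher number here means a weaker inhibitor of growth, a lower number a stronger inhibitor of growth), compound 1 gives 507 nM.
Compound 2, `CC(C)c1n[nH]c2c(NCc3ccc(-c4ccccn4)cc3)nc(SCCCO)nc12`: in this assay compound 2 gives 109 nM.
Compound 3, `CC(C)c1n[nH]c2c(NCc3ccc(-c4ccccn4)cc3)nc(SC3CCCCC3O)nc12`: in this assay compound 3 gives 636 nM.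

Compound 3 has the highest of the three numbers. Its gap to compound 1 is small, a 1.3-fold higher number from compound 1 to compound 3 (0.10 log units; within the scatter), while the step of a 5.8-fold higher number from compound 2 to compound 3 (0.77 log units; beyond the scatter) is a clear one.

Compound 4, `COCSc1nc(NCc2ccc(-c3ccccn3)cc2)c2[nH]nc(C(C)C)c2n1`, differs from compound 3 at the sulfur: methoxymethyl in place of 2-hydroxycyclohexyl on a sulfur.

Among the compounds with values here, two measured steps bear on this. The step of a 4.7-fold lower number from compound 1 to compound 2 (0.67 log units; beyond the scatter) shows a shorter, unbranched chain on the sulfur giving a lower number, and the step of a 5.8-fold higher number from compound 2 to compound 3 (0.77 log units; beyond the scatter) shows the ring giving a higher one. Both point the same way: the smaller group entering in compound 4 should lower the number. Within the data shown here, no measured step tests the loss of the hydroxyl donor, so the size is uncertain. Compound 4 is therefore expected to show a modest downward step, a 2.5-fold lower number from compound 3 to compound 4 (0.41 log units; beyond the scatter), with an estimated value of 250 nM in this assay, within a range of 80 nM to 800 nM.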

Compound 4, concentration for 50% growth inhibition: 340 nM
The estimate for compound 4 lay 1.4-fold (0.13 log units) below the measured number; measured number inside the range.
By their numbers in this assay, from the lowest: compound 2; then compounds 4, 1 and 3 (each within the scatter of the next).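

The hydroxyl is not required for a number in this range at the sulfur: methoxymethyl, with no ring and no hydrogen-bond donor, stands level with both hydroxylated groups in this assay, with a 1.9-fold lower number from compound 3 to compound 4 (0.27 log units; within the scatter) and a 1.5-fold lower number from compound 1 to compound 4 (0.17 log units; within the scatter) as its steps. Compound 2 goes against this picture, since its 3-hydroxypropyl group stays apart, with a 3.1-fold higher number from compound 2 to compound 4 (0.49 log units; beyond the scatter) as the step. Nothing measured here explains why these groups give these numbers.

The compounds shown leave open whether the lower number of compound 2 depends on its terminal hydroxyl or on the length of its chain. A 3-methoxypropyl group on the sulfur would separate the two, and a terminal amine or carboxylic acid on the same chain would show how far that chain end tolerates change.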